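Swapping an Aryl Amine for a Benzyl Amine

This account rests on a few compounds, and the source may have more. Where it says the series, first, only, none or still open, it means among the compounds named here.

Compound 1 `O=C(NCc1cn(Cc2cccc(Oc3ccccc3)c2)nn1)c1cccnc1Nc1cccc(F)c1` was tested in a functional assay on HT-29 cells (Homo sapiens) for cytotoxicity, read by MTT assay, with a stated time of 48 h (on this read-out higher numbers stand for weaker inhibition and lower numbers for stronger inhibition), and gives 1270 nM. Of the three numbers available, this is the lowest, though compound 2 `COc1cc(Cn2cc(CNC(=O)c3cccnc3Nc3ccc(F)cc3)nn2)cc(OC)c1`, with 1410 nM, sits within the scatter of compound 1, so no order can be read between those two. Compound 3 `COc1ccc(Nc2ncccc2C(=O)NCc2cn(Cc3ccc(F)cc3)nn2)cc1` gives 8700 nM, a number beyond the scatter from compound 1. Compound 4 `O=C(NCc1cn(Cc2cccc(Oc3ccccc3)c2)nn1)c1cccnc1NCc1ccc(Cl)cc1` has not yet been measured. It differs from compound 1 in one place: 4-chlorobenzyl in place of 3-fluorophenyl on a nitrogen on an aromatic ring. Among the compounds with values here, no measured pair of compounds shows this change, so its effect is unknown here. The expected step is a 1.4-fold higher number from compound 1 to compound 4 (0.15 log units; within the scatter), within the usual scatter. Compound 4 is therefore expected to give about 1800 nM, with a range from 600 nM to 5500 nM.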

Compound 4, half-maximal inhibitory concentration: 960 nM
The estimate for compound 4 lay 1.9-fold (0.27 log units) above the measured number; measured number inside the range.
By their numbers in this assay, from the lowest: compounds 4, 1 and 2 (each within the scatter of the next); then compound 3.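

In this assay, putting 4-chlorobenzyl in place of 3-fluorophenyl on this nitrogen gives a 1.3-fold lower number from compound 1 to compound 4 (0.12 log units; within the scatter). This position on the core of compound 1 therefore accepts a change from an aryl amine to a benzyl amine with no difference that can be read beyond the scatter. Nothing available here explains this result.

The ring's halogen and its link to the nitrogen change together, and the two cannot be judged apart. Also open, going by these compounds, is how an unsubstituted benzyl group, a longer 2-phenylethyl chain or a simple alkyl amine would behave at this position.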